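Swapping a Methyl Phenyl for a Formyl Phenyl

The source may hold more compounds than are shown below. What is called first, only, known or untested is meant among the compounds shown, and "the series" means these compounds.

Compound 3 `Cc1cccc(-c2cn3ccnc3c(-c3ccc4ncn(Cc5ccccc5)c4c3)n2)c1` gives 18.2% in a functional assay on HL-60 cells (Homo sapiens) for inhibition, read by sulforhodamine B assay, with a stated time of 48 h, tested at 10 uM (a lower number here means less inhibition, a higher number more inhibition at the concentration tested (going by the name of the read-out)), the second highest of three numbers. Its nearest neighbour is compound 1 `O=Cc1ccc(-c2cn3ccnc3c(-c3ccc4ncn(C5CCCCC5)c4c3)n2)cc1` with 16.5%, within the scatter, and compound 2 `CCc1ccc(-c2cn3ccnc3c(-c3ccc4ncn(Cc5ccccc5)c4c3)n2)cc1` with 39.6% stands furthest away, beyond the scatter. Going by the values given here, the single measured step, a number 21.4 percentage points lower from compound 2 to compound 3 (beyond the scatter), concerns a different swap and does not bear on the present change. Compound 4 `O=Cc1ccc(-c2cn3ccnc3c(-c3ccc4ncn(Cc5ccccc5)c4c3)n2)cc1` carries 4-formylphenyl in place of 3-methylphenyl on an aromatic carbon. Compound 1 already bears this same 4-formylphenyl group, though it differs from compound 4 elsewhere, and its value sits close to that of compound 3. The step of a number 0.2 percentage points lower from compound 3 to compound 4 (within the scatter) is therefore expected to stay within the scatter. Compound 4 is estimated at 18%, with a range from 5% to 35%.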

Compound 4, a percentage reported as inhibition, at one concentration (the size of the read-out at that concentration, not a potency): 16.5%
For compound 4 the middle estimate is 1.5 percentage points above the measured one, and the stated range covers the measured number.
By their numbers in this assay, from the lowest: compounds 1, 4 and 3 (each within the scatter of the next); then compound 2.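

In this assay, 4-formylphenyl and 3-methylphenyl on this aromatic carbon read alike (a number 1.7 percentage points lower from compound 3 to compound 4 (within the scatter)). Formyl in place of ethyl gives a clear drop (a number 23.1 percentage points lower from compound 2 to compound 4 (beyond the scatter)), so among these groups, only the 4-ethylphenyl of compound 2 stands apart. With the 4-formylphenyl group kept, benzyl in place of cyclohexyl on the aromatic nitrogen makes no difference (no change at the digits printed from compound 1 to compound 4 (within the scatter)).

No supporting data explain the ethyl result. As far as these compounds go, whether a propyl chain or a carboxylic acid on this phenyl ring would read like compound 2 or compound 4 stays open.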